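Extending the Methoxy of Compound 3 to a Methoxyethoxy

The compounds below may be only part of what the source reports. "The series", "measured", "known", "first", "only" and "open" are said of these compounds alone.

In an assay on blood for inhibition of C-X-C chemokine receptor type 3 (Homo sapiens), with a stated time of 30 min (a higher number here means a weaker inhibitor, a lower number a stronger inhibitor), compound 3 `COc1ncc(-c2nc(C(F)(F)F)sc2N2CCN(C(=O)Cn3cnc4cccnc43)[C@H](C)C2)cn1` gives 158 nM, the lowest of the three numbers: compound 1 `C[C@@H]1CN(c2sc(Br)nc2-c2nc3ccccc3[nH]2)CCN1C(=O)Cn1cnc2cccnc21` gives 526 nM and compound 2 `C[C@@H]1CN(c2sc(CN(C)C)nc2-c2nc3ccccc3[nH]2)CCN1C(=O)Cn1cnc2cccnc21` gives 1150 nM. Within the data shown here, the only single-place step that has been measured, a 2.2-fold higher number from compound 1 to compound 2 (0.34 log units; beyond the scatter), concerns a different part of the shared core and does not bear on the change at hand. Compound 4 `COCCOc1ncc(-c2nc(C(F)(F)F)sc2N2CCN(C(=O)Cn3cnc4cccnc43)[C@H](C)C2)cn1` differs from compound 3 by methoxymethyl in place of hydrogen on a saturated chain carbon bound to an oxygen on an aromatic ring. Among the measured compounds shown here, no measured pair tests this position, so there is no ground to expect a step beyond the scatter in this assay, in either direction. Compound 4 is therefore estimated at 200 nM, between 80 nM and 500 nM. The expected step of a 1.3-fold higher number from compound 3 to compound 4 (0.10 log units; within the scatter) is small and of uncertain direction.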

Compound 4, half-maximal inhibitory concentration: 182 nM
For compound 4 the middle estimate is 1.1-fold (0.04 log units) above the measured one, and the stated range covers the measured number.
By their numbers in this assay, from the lowest: compounds 3 and 4 (each within the scatter of the next); then compound 1; then compound 2.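

In this assay, among these compounds, extending methoxy to 2-methoxyethoxy gives a 1.2-fold higher number from compound 3 to compound 4 (0.06 log units; within the scatter) and so offers the first reading at this position: methoxymethyl in place of hydrogen on this saturated chain carbon leaves the number within the scatter. That tolerance rests on this single pair and covers only this one chain. Nothing shown accounts for the outcome.

On these data alone, whether a longer chain or one ending in an amine or a carboxylic acid would also stay within the scatter of compound 3 remains open.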